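Methoxy for Bromo: Expected Solubility of Compound 3

The source may hold more compounds than are shown below. What is called first, only, known or untested is meant among the compounds shown, and "the series" means these compounds.

Compound 1, `CNC(=O)c1cc(Oc2ccc3nc(Nc4cccc(Br)c4)ncc3c2)ccn1`: in a physicochemical assay for solubility, at pH 7 (a lower number here means a less soluble compound, a higher number a more soluble compound), compound 1 gives < 1000 nM, which is a limit of the assay.
Compound 2, `CNC(=O)c1cc(Oc2ccc3nc(Nc4ccc(Br)cc4)ncc3c2)ccn1`: in this assay compound 2 gives < 1000 nM, which is also a limit of the assay.

Compound 2 therefore stands at a limit, not at a number, and the same holds for both values shown (the limit of < 1000 nM in this assay, at which 2 of the 2 values shown sit). Among the measured compounds shown here, the only measured step, a step that the two limits leave unreadable from compound 1 to compound 2, cannot be read for size or direction, so it gives no guide.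

Compound 3, `CNC(=O)c1cc(Oc2ccc3nc(Nc4ccc(OC)cc4)ncc3c2)ccn1`, differs from compound 2 by methoxy in place of bromo on an aromatic carbon. For the measured compounds named here, no measured step bears on this change, and no measured property of either group is available. The expected step of an at least 1.5-fold higher number from compound 2 to compound 3 (0.17 log units; that floor lies within the scatter) is thus uncertain, and compound 3 is estimated at 1500 nM, within 300 nM to 8000 nM, with a real chance that compound 3 again returns only a limit.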

Compound 3, solubility: < 1000 nM
Compound 3: no number, only a limit (the forecaster's own chance of this, stated with the estimate: 45%); middle value at least 1.5-fold (0.17 log units) away from the limit.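

In this assay compound 3 gives < 1000 nM, which is a limit of the assay and not a number. The steps among compound 1, compound 2 and compound 3 therefore cannot be read for size or direction: the limit of < 1000 nM in this assay, at which 3 of the 3 values shown sit.

The compounds shown leave open whether methoxy in place of bromo, from compound 2 to compound 3, changes solubility at all.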